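Permeability of a Pyrazolopyrimidinone Pair and an Azetidine Analogue

The compounds below may be only part of what the source reports. "The series", "measured", "known", "first", "only" and "open" are said of these compounds alone.

Compound 1 `CCc1c2nc(-c3cc(S(=O)(=O)N4CCN(CC)CC4)cnc3OCC(C)C)[nH]c(=O)c2nn1CCOC` gives 40 10^-6 cm/s in an ADME assay on Caco-2 cells (Homo sapiens) for permeability, in the apical to basolateral direction, tested at 25 uM; a lower number here means that the compound crosses the layer more slowly, a higher number that the compound crosses the layer faster.
Compound 2 `CCCCOc1ncc(S(=O)(=O)N2CCN(CC)CC2)cc1-c1nc2c(CC)n(CCN(C)C)nc2c(=O)[nH]1` gives 2.8 10^-6 cm/s in this assay.

Going by the values given here, of the two compounds measured so far, compound 2 stands lowest in this assay, and its gap to compound 1 lies beyond the usual scatter. Compound 3 `CCCCOc1ncc(S(=O)(=O)N2CCN(CC)CC2)cc1-c1nc2c(CC)n(C3CN(C)C3)nc2c(=O)[nH]1` has not yet been measured. It differs from compound 2 in one place: 1-methylazetidin-3-yl in place of 2-(dimethylamino)ethyl on an aromatic nitrogen. Among the compounds with values here, no comparable step between measured compounds is available, so the size of the change in this assay can only be guessed. The step from compound 2 to compound 3 is expected to be small, within the scatter, a 1.3-fold higher number from compound 2 to compound 3 (0.10 log units; within the scatter). Compound 3 is therefore estimated at 3.5 10^-6 cm/s, with a range from 1.5 10^-6 cm/s to 8 10^-6 cm/s.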

Compound 3, apparent permeability in the Caco-2 assay: 6 10^-6 cm/s
Estimate against measurement, compound 3: 1.7-fold (0.23 log units) below; the measured number falls inside the stated range.
By their numbers in the Caco-2 assay, from the lowest: compound 2; then compound 3; then compound 1.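

Putting the ring of 1-methylazetidin-3-yl in place of the open 2-(dimethylamino)ethyl chain, with the same count of heavy atoms, gives in the Caco-2 assay a 2.1-fold higher number from compound 2 to compound 3 (0.33 log units; beyond the scatter), a modest step but the first one measured at this position. In a physicochemical assay for lipophilicity, at pH 7.4 (on this read-out higher numbers stand for higher lipophilicity and lower numbers for lower lipophilicity), compound 2 gives 3 and compound 3 gives 2.8, two values within the usual scatter of each other. Nothing available explains the step in crossing the cell layer.

From the compounds shown here alone, what a larger ring such as 1-methylpiperidin-4-yl would do on this nitrogen stays open. So does whether the step would hold with another chain in place of the butoxy group.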